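The source may hold more compounds than are shown below. What is called first, only, known or untested is meant among the compounds shown, and "the series" means these compounds.

Measured in a physicochemical assay for pharmacokinetics, read by LC-MS, in phosphate buffer, tested at 1 uM; on this read-out lower numbers stand for a shorter-lived compound and higher numbers for a longer-lived compound:
- compound 1 `C#CCNC(=O)c1cccc2c1cc(C)n2-c1nc2c(c(NCc3ccccc3)n1)COCC2`: > 24 h (a limit of the assay, not a number)
- compound 2 `C#CC(=O)Nc1cccc2c1cc(C)n2-c1nc2c(c(NCc3ccccc3)n1)COCC2`: 0.21 h
- compound 3 `CC#CC(=O)Nc1cccc2c1cc(C)n2-c1nc2c(c(NCc3ccccc3)n1)COCC2`: 16.2 h

Of the two true numbers, compound 3 holds the higher, with a 77-fold higher number from compound 2 to compound 3 (1.89 log units; beyond the scatter). Against compound 1 there is only a floor, an at least 1.4-fold lower number from compound 1 to compound 3 (0.17 log units; that floor lies within the scatter).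

The next compound is compound 4 `C=CC(=O)Nc1cccc2c1cc(C)n2-c1nc2c(c(NCc3ccccc3)n1)COCC2`, and the change is vinyl in place of prop-1-yn-1-yl on a carbonyl carbon. For the measured compounds named here, no measured step makes this exchange. The closest evidence comes from the compounds that carry a group on the same carbonyl. The step of a 77-fold higher number from compound 2 to compound 3 (1.89 log units; beyond the scatter) is large and shows that a change at this end of the chain can move the half-life strongly. The step of an at least 110-fold lower number from compound 1 to compound 2 (2.05 log units; beyond the scatter) is also large, but it replaces the whole amide link and so says less. Compound 4 keeps neither triple bond, so compound 2 at 0.21 h and compound 3 at 16.2 h serve only as rough guides.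

The expected change is a 2.3-fold lower number from compound 3 to compound 4 (0.36 log units; beyond the scatter), a modest estimated drop with an uncertain size. The estimate for compound 4 is 7 h, expected to fall between 1.5 h and 24 h.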

Compound 4, half-life: 4.31 h
Estimate against measurement, compound 4: 1.6-fold (0.21 log units) above, within the range that was stated.
By their numbers in this assay, from the lowest: compound 2; then compound 4; then compound 3. At a limit, above all of these: compound 1.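

In this assay, the group on this carbonyl carbon now spans three distinct levels, since vinyl falls short of prop-1-yn-1-yl, a 3.8-fold lower number from compound 3 to compound 4 (0.58 log units; beyond the scatter), yet stands well clear of ethynyl, a 21-fold higher number from compound 2 to compound 4 (1.31 log units; beyond the scatter). The earlier compounds shown here showed only that adding a methyl to the triple-bonded carbon moved the half-life strongly, whereas compound 4 shows that a short half-life does not follow from simply having an unsubstituted end on this carbonyl, as vinyl sits between the two triple-bonded groups, and the step from the propargylcarbamoyl compound, an at least 5.5-fold lower number from compound 1 to compound 4 (0.74 log units; beyond the scatter), is beyond the scatter even as a floor. Compound 1 stands at a limit of the assay and not at a number, so its steps give only a floor: the limit of > 24 h in this assay, at which 1 of the 4 values shown sits.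

The compounds shown leave open where a saturated propanoyl group on the same carbonyl, or a vinyl end carrying a methyl or a dimethylamino group, would fall among these three levels. They also leave open what chemical change the half-life in this assay follows, and whether the order of the three groups would hold on another core.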